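The source may report more compounds than this note shows. Statements on the series, on what has been measured and on what is new or still open speak of the compounds shown alone.

Measured so far:
compound 1 `COc1ccc(-c2c(S(=O)(=O)c3cc(Cl)cc(Cl)c3)cnc3c(F)cccc23)cc1` gives 2.11 mL/min
compound 2 `COc1ccc(-c2c(S(=O)(=O)c3ccc(OC)cc3)cnc3c(F)cccc23)cc1` gives 2.12 mL/min
compound 3 `O=S(=O)(c1cc(Cl)cc(Cl)c1)c1cnc2cc(F)ccc2c1-c1cccc(F)c1` gives 0.41 mL/min

Of the compounds shown here, three have been measured in an ADME assay on microsomes from liver (Homo sapiens) for metabolic stability, tested at 2.5 uM; on this read-out lower numbers stand for slow clearance and higher numbers for fast clearance. Compound 1 and compound 2 share one core and differ by a single change, (4-methoxyphenyl in place of 3,5-dichlorophenyl on a sulfonyl sulfur); that step, a 1.0-fold higher number from compound 1 to compound 2 (0.00 log units; within the scatter), left the number essentially where it was. Compound 3 sits on a different core, and the difference between the two cores is not broken down here; compound 3 holds the lowest number of the three, and its values beside those of compound 1 and compound 2 show a clear gap in this assay.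

Compound 4 `COc1ccc(S(=O)(=O)c2cnc3cc(F)ccc3c2-c2cccc(F)c2)cc1` has not yet been measured. It relates to compound 3 exactly as compound 2 relates to compound 1: 4-methoxyphenyl in place of 3,5-dichlorophenyl on a sulfonyl sulfur. Because the earlier step of a 1.0-fold higher number from compound 1 to compound 2 (0.00 log units; within the scatter) was flat, the expectation for compound 4 is a step of about a 1.1-fold higher number from compound 3 to compound 4 (0.04 log units; within the scatter) from compound 3. In this assay compound 4 is therefore estimated at 0.45 mL/min, with a likely range from 0.2 mL/min to 1 mL/min.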

Compound 4, intrinsic clearance in a liver preparation (reported as CLH), per the amount of preparation that the assay uses: 2.94 mL/min
Compound 4: the middle estimate sits 6.5-fold (0.82 log units) below what was measured; measured number above the stated range.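

In this assay, putting 4-methoxyphenyl in place of 3,5-dichlorophenyl on the sulfonyl sulfur gave a 7.2-fold higher number from compound 3 to compound 4 (0.86 log units; beyond the scatter), so on this core the change clearly matters. Set beside the same change on the other core, the two steps do not agree: the same change on two cores in this assay, a 1.0-fold higher number (0.00 log units; within the scatter) from compound 1 to compound 2 and a 7.2-fold higher number (0.86 log units; beyond the scatter) from compound 3 to compound 4, 7.1-fold (0.85 log units) apart, beyond the scatter of two such steps This shows that the effect of the change does not carry over unchanged between these two cores, so a flat step on one core is a poor guide to the step on the other, but it rests on only two pairs and does not show which part of the core makes the difference, or why.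

The compounds shown leave open whether other groups on the sulfonyl sulfur, such as plain phenyl, a short alkyl chain or a phenyl ring carrying an amine or a carboxylic acid, would also behave differently on the two cores. Also open, going by these compounds, is which single difference between the cores matters, something that compounds differing from either core in only one place could begin to answer.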